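Side chain variation at the amide-bearing carbon

The compounds below may be only part of what the source reports. "The series", "measured", "known", "first", "only" and "open" are said of these compounds alone.

compound 1 `NCCCC[C@H](NC(=O)CN(c1nc(Cl)nc2[nH]cnc12)C1CC1)C(=O)OCc1ccccc1`: 41.2%
compound 2 `CC[C@H](C)[C@H](NC(=O)CN(c1ncnc2c1ncn2C1CCCCO1)C1CC1)C(=O)OCc1ccccc1`: 27.4%
compound 3 `C[C@H](NC(=O)CN(c1ncnc2c1ncn2C1CCCCO1)C1CC1)C(=O)OCc1ccccc1`: 53%

In a functional assay on the whole organism (Tail, strain ICR) with Mus musculus as the target, in the tail flick test, with a stated time of 60 min, at a dose of 25 umol/kg by the oral route (on this read-out higher numbers stand for a stronger effect at the one dose given and lower numbers for a weaker effect), compound 1 gives 41.2%, the second highest of the three numbers; compound 3 stands higher and compound 2 lower, both gaps beyond the scatter. Compound 4 `CC(C)[C@H](NC(=O)CN(c1nc(Cl)nc2[nH]cnc12)C1CC1)C(=O)OCc1ccccc1` differs from compound 1 by isopropyl in place of 4-aminobutyl on a saturated chain carbon bound to an amide-type nitrogen and a carbonyl carbon. Among the compounds with values here, the only measured step at this place is a number 25.6 percentage points higher from compound 2 to compound 3 (beyond the scatter), on the core of compound 2, where a smaller chain in place of a larger one raised the read-out by a modest amount. Within the data shown here, the change to compound 4 also puts a smaller chain in place of a larger one, so a modest rise in this assay is expected, though the shift from a chain with a donor and an acceptor to one without has no measured counterpart here. For compound 4 the expected step is a number 10.8 percentage points higher from compound 1 to compound 4 (beyond the scatter), an estimate of 52% with a range from 32% to 72%.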

Compound 4, a percentage reported as activity, at one dose (the size of the read-out at that dose, not a potency): 55.5%
Estimate against measurement, compound 4: 3.5 percentage points below; the range from low to high includes it.
By their numbers in this assay, from the lowest: compound 2; then compound 1; then compounds 3 and 4 (each within the scatter of the next).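

The read-out in this assay shows a number 14.3 percentage points higher from compound 1 to compound 4 (beyond the scatter), so a smaller chain in place of a larger one also raises it on the core of compound 1, in the same direction as a number 25.6 percentage points higher from compound 2 to compound 3 (beyond the scatter). In this pair, replacing 4-aminobutyl, with its hydrogen-bond donor and acceptor, by isopropyl brings no loss of read-out. No evidence at hand accounts for the rise. The two pairs leave chain size and the terminal amine unseparated, which an unbranched butyl chain on the core of compound 1 would address. Going by these compounds, a chain ending in a carboxylic acid also remains open at this position.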